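The source may hold more compounds than are shown below. What is called first, only, known or untested is meant among the compounds shown, and "the series" means these compounds.

Compound 1 `Cc1ccccc1C(=O)NCc1ccc(CNS(=O)(=O)c2ccccc2C)cc1` gives 10 nM in an assay on MDA-MB-231 cells for displacement of a labelled ligand from C-X-C chemokine receptor type 4 (Homo sapiens), read by fluorescence and microscopy, with stated times of 10 min and 30 min; on this read-out lower numbers stand for an effect already at smaller amounts and higher numbers for an effect only at larger amounts of compound.
Compound 2 `Cc1ccccc1C(=O)NCc1ccc(CNS(=O)(=O)c2ccc(F)cc2)cc1` gives 10 nM.
Compound 3 `Cc1ccccc1C(=O)NCc1ccc(CNS(=O)(=O)c2cccc3ccccc23)cc1` gives 100 nM.

Compound 1 stands level with compound 2, the two together having the lowest numbers of the three, while compound 3 sits furthest away: a 10-fold higher number from compound 1 to compound 3 (1.00 log units; beyond the scatter), and likewise a 10-fold higher number from compound 2 to compound 3 (1.00 log units; beyond the scatter). Between the two low compounds there is no change at the digits printed from compound 1 to compound 2 (within the scatter).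

Compound 4 `Cc1ccccc1S(=O)(=O)NCc1ccc(CNC(=O)c2cccnc2)cc1` has not been measured. Compared with compound 1 the change is pyridin-3-yl in place of 2-methylphenyl on a carbonyl carbon. This is the other side of the shared core from where compounds 2 and 3 differ: every measured step swaps the group on the sulfonyl sulfur, and none touches the group on the carbonyl carbon. So the measured steps give no direct guide. The two measured swaps that kept a single six-membered aromatic ring on the sulfonyl sulfur stayed level with each other, and only the larger ring system moved the number; a single ring for a single ring on the carbonyl carbon is therefore expected to give a 1.5-fold higher number from compound 1 to compound 4 (0.18 log units; within the scatter), or nothing beyond the scatter. For compound 4 the estimate is 15 nM, with a likely range from 5 nM to 60 nM.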

Compound 4, effective concentration (reported as EC, without a stated level of effect): 1000 nM
Compound 4: the middle estimate sits 67-fold (1.82 log units) below what was measured, outside the stated range (above it).
By their numbers in this assay, from the lowest: compounds 1 and 2 (each within the scatter of the next); then compound 3; then compound 4.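

In this assay the group on the carbonyl carbon turns out to matter a great deal: pyridin-3-yl in place of 2-methylphenyl gives a 100-fold higher number from compound 1 to compound 4 (2.00 log units; beyond the scatter), even though one six-membered aromatic ring simply replaces another. On the sulfonyl sulfur, a swap of one such ring for another gave no change at the digits printed from compound 1 to compound 2 (within the scatter), so the two ends of the shared core do not respond alike to this kind of change. The new step is also larger than a 10-fold higher number from compound 1 to compound 3 (1.00 log units; beyond the scatter), the biggest step seen on the sulfonyl sulfur.

This single swap removes a methyl group and brings in a ring nitrogen together, so the compounds shown cannot tell which of the two counts, and a plain phenyl group on the carbonyl carbon would separate them. Nothing available here explains the size of this step.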